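A few compounds are considered here, and "the series" means these few. Any claim that something is new, unique, unknown or untested is made for them only; others in the source may bear on it.

In an ADME assay on HeLa cells (Homo sapiens) for cytotoxicity, read by MTT assay, with a stated time of 2 days (a lower number here means that less compound is tolerated, a higher number that more compound is tolerated), compound 1 (`CCOC(=O)c1sc2cc(Oc3ccnc(C(=O)NC)c3)ccc2c1C`) gives > 100000 nM as a limit of the assay and not a number. Compound 2 (`CCCOC(=O)c1sc2cc(Oc3ccnc(C(=O)NC)c3)ccc2c1C`) gives 57100 nM in this assay as an actual number. Compound 2 carries methyl in place of hydrogen on a saturated chain carbon, two bonds along the chain from an oxygen next to a carbonyl group. Within the data shown here, the change an at least 1.7-fold lower number from compound 1 to compound 2 (0.24 log units; that floor lies within the scatter) is the only measured step available, and its true size stays open given the limit of > 100000 nM in this assay, at which 1 of the 2 values shown sits, in these data. Compound 3 (`CCOC(=O)c1sc2cc(Oc3ccnc(C(=O)NC)c3)ccc2c1Cl`) keeps the core of compound 1, and the difference chloro in place of methyl on an aromatic carbon amounts to chloro in place of methyl on an aromatic carbon. Among the measured compounds shown here, that is not the chain carbon changed in compound 2, so the single measured step offers only weak guidance. No step beyond the scatter is therefore expected in this assay, and compound 3 may also end at the limit of the assay. The expected change is an at least 1.2-fold lower number from compound 1 to compound 3 (0.09 log units; that floor lies within the scatter) on this reasoning. Compound 3 is estimated at 80000 nM with an expected range of 35000 nM to 150000 nM around that figure.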

Compound 3, half-maximal cytotoxic concentration: 45600 nM
For compound 3 the middle estimate is 1.8-fold (0.24 log units) above the measured one; the measured number falls inside the stated range.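

In this assay, putting chloro in place of methyl on an aromatic carbon of the five-membered aromatic ring with 1 sulfur gives an at least 2.1-fold lower number from compound 1 to compound 3 (0.34 log units; beyond the scatter). Among these compounds, this is the first step that is printed as beyond the scatter, which shows that this ring position can move the tolerated concentration, whereas the floor of the chain change, an at least 1.7-fold lower number from compound 1 to compound 2 (0.24 log units; that floor lies within the scatter), could not show that for the chain carbon. Compound 1 gives > 100000 nM, which is a limit of the assay and not a number, so the step is known only as a floor and its real size may be larger: the limit of > 100000 nM in this assay, at which 1 of the 3 values shown sits.

The compounds shown hold only methyl and chloro at this aromatic carbon, so they leave open how a plain hydrogen, bromo or a nitrile would read there. They also leave open whether the same swap would give a similar step with the longer chain of compound 2, or with a carboxylic acid in place of the ethoxycarbonyl group.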